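Azetidine amide in place of methylamide on compound 1

A few compounds are considered here, and "the series" means these few. Any claim that something is new, unique, unknown or untested is made for them only; others in the source may bear on it.

compound 1 `CNC(=O)/C=C/CNCCOc1ccc(Oc2c(-c3ccc(F)cc3)sc3cc(O)ccc23)cc1`: 15500 nM
compound 2 `C/C=C/C(=O)NCCOc1ccc(Oc2c(-c3ccc(F)cc3)sc3cc(O)ccc23)cc1`: 12400 nM
compound 3 `CNC(=O)/C=C/CN1CC(Oc2ccc(Oc3c(-c4ccc(F)cc4)sc4cc(O)ccc34)cc2)C1`: > 25000 nM, a limit of the assay

In a functional assay on Ishikawa cells (Homo sapiens) for antiproliferative activity, read by CCK-8 assay, with a stated time of 48 h (on this read-out higher numbers stand for weaker inhibition and lower numbers for stronger inhibition), compound 1 stands highest of the two numbers; compound 2 sits a 1.3-fold lower number from compound 1 to compound 2 (0.10 log units; within the scatter). For compound 3 only a limit is reported, (the limit of > 25000 nM in this assay, at which 1 of the 3 values shown sits); the step from compound 1 is an at least 1.6-fold higher number from compound 1 to compound 3 (0.20 log units; that floor lies within the scatter).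

Compound 4 `O=C(/C=C/CNCCOc1ccc(Oc2c(-c3ccc(F)cc3)sc3cc(O)ccc23)cc1)N1CCC1` differs from compound 1 by azetidin-1-yl in place of methylamino on a carbonyl carbon. Among the compounds with values here, no measured step alters the group on this carbonyl carbon: the step of a 1.3-fold lower number from compound 1 to compound 2 (0.10 log units; within the scatter) changes the amine nitrogen instead, and the step of an at least 1.6-fold higher number from compound 1 to compound 3 (0.20 log units; that floor lies within the scatter) moves an azetidine into the linker. Neither bears directly, so no step beyond the scatter is expected, a 1.0-fold lower number from compound 1 to compound 4 (0.01 log units; within the scatter). Compound 4 is therefore estimated at 15000 nM, with a range from 6000 nM to 40000 nM.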

Compound 4, half-maximal inhibitory concentration: 6560 nM
Estimate against measurement, compound 4: 2.3-fold (0.36 log units) above, and the stated range covers the measured number.
By their numbers in this assay, from the lowest: compounds 4, 2 and 1 (each within the scatter of the next, the first and the last beyond it). At a limit, above all of these: compound 3.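

In this assay, within the data shown here, azetidin-1-yl in place of methylamino on a carbonyl carbon gives a single-change step beyond the scatter (a 2.4-fold lower number from compound 1 to compound 4 (0.37 log units; beyond the scatter)), which no earlier step showed, while no order can be read against compound 2 (a 1.9-fold lower number from compound 2 to compound 4 (0.28 log units; within the scatter)). The step to compound 4 from compound 3 (an at least 3.8-fold lower number from compound 3 to compound 4 (0.58 log units; beyond the scatter)) alters both the linker and the carbonyl group, so it cannot be read for this position alone. The value of compound 3 is a limit, not a number: the limit of > 25000 nM in this assay, at which 1 of the 4 values shown sits.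

Open, going by these compounds, is whether pyrrolidin-1-yl or dimethylamino on the same carbonyl carbon would move the number further. Also open, on these data alone, is whether the azetidine amide would change the reading on the azetidine linker of compound 3.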